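Aryl group on the aromatic nitrogen: toward compound 4

The source may hold more compounds than are shown below. What is called first, only, known or untested is meant among the compounds shown, and "the series" means these compounds.

compound 1 `COc1cc2c(Oc3ccc(NC(=O)c4nn(-c5ccccc5C(F)(F)F)c(=O)cc4C)cc3F)ccnc2cc1OCCCN1CCCC1`: 210 nM
compound 2 `COc1cc2c(Oc3ccc(NC(=O)c4nn(-c5ccccc5OC(F)(F)F)c(=O)cc4C)cc3F)ccnc2cc1OCCCN1CCCC1`: 210 nM
compound 3 `COc1cc2c(Oc3ccc(NC(=O)c4nn(-c5cccc(F)c5)c(=O)cc4C)cc3F)ccnc2cc1OCCCN1CCCC1`: 280 nM

Measured in a functional assay on NCI-H460 cells (Homo sapiens) for inhibition, read by MTT assay, with a stated time of 72 h (on this read-out lower numbers stand for stronger inhibition and higher numbers for weaker inhibition), compound 3 gives the highest of the three numbers, but only by a 1.3-fold higher number from compound 1 to compound 3 (0.12 log units; within the scatter) and a 1.3-fold higher number from compound 2 to compound 3 (0.12 log units; within the scatter), both within the scatter. Compound 4 `COc1ccc(-n2nc(C(=O)Nc3ccc(Oc4ccnc5cc(OCCCN6CCCC6)c(OC)cc45)c(F)c3)c(C)cc2=O)cc1` carries 4-methoxyphenyl in place of 3-fluorophenyl on an aromatic nitrogen. Among the measured compounds shown here, the steps that bear on this change are no change at the digits printed from compound 1 to compound 2 (within the scatter), a 1.3-fold higher number from compound 1 to compound 3 (0.12 log units; within the scatter) and a 1.3-fold higher number from compound 2 to compound 3 (0.12 log units; within the scatter); each swap of the aryl group on this nitrogen left this assay within the scatter. No step beyond the scatter is therefore expected for a 4-methoxyphenyl either. Compound 4 is estimated at 250 nM, with a range from 120 nM to 520 nM, which means an expected step of a 1.1-fold lower number from compound 3 to compound 4 (0.05 log units; within the scatter).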

Compound 4, half-maximal inhibitory concentration: 3610 nM
The estimate for compound 4 lay 14-fold (1.16 log units) below the measured number; the whole stated range lies below it.
By their numbers in this assay, from the lowest: compounds 1, 2 and 3 (each within the scatter of the next); then compound 4.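

In this assay the aryl group on this nitrogen proves able to move the number: 4-methoxyphenyl gives a 13-fold higher number from compound 3 to compound 4 (1.11 log units; beyond the scatter), a 17-fold higher number from compound 2 to compound 4 (1.24 log units; beyond the scatter) and a 17-fold higher number from compound 1 to compound 4 (1.24 log units; beyond the scatter). The tolerance seen among compound 1, compound 2 and compound 3 therefore does not extend to every aryl group at this place. Nothing available here accounts for this step.

Open, on these data alone, is whether the step belongs to the methoxy group itself or to the aryl group as a whole. A plain phenyl or a 4-aminophenyl on this nitrogen would bear on that.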